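The compounds below may be only part of what the source reports. "The series", "measured", "known", "first", "only" and "open" are said of these compounds alone.

Compound 1 `COCc1ccc(F)c(C#Cc2cc(Cl)ccc2OCC(=O)O)c1` gives 72 nM in an assay on CHO cells for displacement of a labelled ligand from prostaglandin D2 receptor 2 (Homo sapiens), read by scintillation counting; on this read-out higher numbers stand for weaker inhibition and lower numbers for stronger inhibition. Compound 2 `O=C(O)COc1ccc(Cl)cc1C#Cc1cc(CO)ccc1F` gives 73 nM in this assay. The two differ by methyl in place of hydrogen on an oxygen on a saturated carbon, and that step, a 1.0-fold lower number from compound 2 to compound 1 (0.01 log units; within the scatter), lies within the scatter, so nothing is read into the relative standing of these two values. Compound 3 `CC1(O)c2ccc(C#Cc3cc(Cl)ccc3OCC(=O)O)cc2S(=O)(=O)C1(C)C` has a different core; how its core differs from that of compound 2 is not broken down here. In this assay compound 3 gives 28 nM, the lowest of the three numbers, its steps to compound 1 and to compound 2 both lying beyond the scatter.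

Compound 4 `COC1(C)c2ccc(C#Cc3cc(Cl)ccc3OCC(=O)O)cc2S(=O)(=O)C1(C)C` is not yet measured. It differs from compound 3 by methyl in place of hydrogen on an oxygen on a saturated carbon. This is the same kind of change as that from compound 2 to compound 1, though what surrounds the place differs: in compound 2 the other neighbour of the saturated carbon is a saturated chain carbon, in compound 3 it is a saturated ring carbon. Because the earlier step of a 1.0-fold lower number from compound 2 to compound 1 (0.01 log units; within the scatter) was within the scatter, a similarly small step is expected in this assay, a 1.1-fold higher number from compound 3 to compound 4 (0.03 log units; within the scatter). Compound 4 is therefore expected to give about 30 nM, with a range from 12 nM to 75 nM.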

Compound 4, inhibition constant: 25 nM
Compound 4: the middle estimate sits 1.2-fold (0.08 log units) above what was measured; low and high end bracket the measured number.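

In this assay the change from hydroxy to methoxy gives a 1.1-fold lower number from compound 3 to compound 4 (0.05 log units; within the scatter), a step as small on this core as on the earlier one. Set side by side, the two cores do not part on this change: the same change on two cores in this assay, a 1.0-fold lower number (0.01 log units; within the scatter) from compound 2 to compound 1 and a 1.1-fold lower number (0.05 log units; within the scatter) from compound 3 to compound 4, 1.1-fold (0.04 log units) apart, within the scatter of two such steps. The change therefore carries from one core to the other in this series as a step within the scatter. Within the data shown here, this rests on only two matched pairs in a single assay and says nothing about other cores or other read-outs.

The compounds shown leave open whether the oxygen on the saturated carbon tolerates anything larger than methyl, such as an ethyl group or a longer chain, since hydroxy and methoxy are the only two forms present. They also leave open whether an amine or a fluorine in place of the hydroxy would give a similarly small step on either core.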